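Replacing bromo by methoxy at the para position of compound 3

A few compounds are considered here, and "the series" means these few. Any claim that something is new, unique, unknown or untested is made for them only; others in the source may bear on it.

Compound 1 `COc1ccc2c(c1)c(C1CC(c3ccccc3)=NN1C(=O)c1ccc(OC)nc1)cn2C` gives 1110 nM in a functional assay on A549 cells (Homo sapiens) for inhibition, read by MTT assay, with a stated time of 48 h (a lower number here means a stronger inhibitor of growth, a higher number a weaker inhibitor of growth), and compound 2 `COc1ccc2c(c1)c(C1CC(c3ccc(F)cc3)=NN1C(=O)c1ccc(OC)nc1)cn2C` gives 710 nM, so a 1.6-fold lower number from compound 1 to compound 2 (0.19 log units; within the scatter). Compound 3 `COc1ccc2c(c1)c(C1CC(c3ccc(Br)cc3)=NN1C(=O)c1ccc(OC)nc1)cn2C` reaches only > 10000 nM, which is a limit of the assay rather than a number (the limit of > 10000 nM in this assay, at which 1 of the 3 values shown sits). Thus an at least 9.0-fold higher number from compound 1 to compound 3 (0.95 log units; beyond the scatter) and an at least 14-fold higher number from compound 2 to compound 3 (1.14 log units; beyond the scatter) place compound 3 as the weakest of the three. Compound 4 `COc1ccc(C2=NN(C(=O)c3ccc(OC)nc3)C(c3cn(C)c4ccc(OC)cc34)C2)cc1` differs from compound 3 by methoxy in place of bromo on an aromatic carbon. Within the data shown here, no measured step covers methoxy at this position; the steps show only that bromo there weakens growth inhibition. Compound 4 is therefore expected to return toward the numbers of compound 1 and compound 2, giving an at least 6.6-fold lower number from compound 3 to compound 4 (0.82 log units; beyond the scatter) as the estimated step, and an estimated value of 1500 nM (range 400 nM to 10000 nM).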

Compound 4, concentration for 50% growth inhibition: 450 nM
Beside the measured number, compound 4's estimate is 3.3-fold (0.52 log units) above it; the measured number falls inside the stated range.
By their numbers in this assay, from the lowest: compounds 4, 2 and 1 (each within the scatter of the next, the first and the last beyond it). At a limit, above all of these: compound 3.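

In this assay, among these compounds, methoxy is the first group at this position to give a step from the unsubstituted phenyl that lies beyond the scatter: a 2.5-fold lower number from compound 1 to compound 4 (0.39 log units; beyond the scatter). It cannot be told apart from fluoro, a 1.6-fold lower number from compound 2 to compound 4 (0.20 log units; within the scatter), while the loss seen with bromo does not carry over to methoxy, an at least 22-fold lower number from compound 3 to compound 4 (1.34 log units; beyond the scatter). That last step rests on a limit, not a number: the limit of > 10000 nM in this assay, at which 1 of the 4 values shown sits.

The compounds shown leave open whether chloro follows bromo or fluoro at this position. They also leave open whether an amine or a longer chain such as ethoxy would hold the level of compound 4.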